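Chromene series: nitro for hydroxy on the carbonyl-borne phenyl

The source may hold more compounds than are shown below. What is called first, only, known or untested is meant among the compounds shown, and "the series" means these compounds.

Measured so far:
compound 1 `CCC(=O)c1ccc2c(c1)C(n1ccccc1=O)=CC(C)(C)O2` — 5.85
compound 2 `COc1ccc(C(=O)c2ccc3c(c2)C(n2ccccc2=O)=CC(C)(C)O3)cc1` — 5.72
compound 3 `CC1(C)C=C(n2ccccc2=O)c2cc(C(=O)c3ccc(O)cc3)ccc2O1` — 5.87

In a functional assay (trachea) with Rattus norvegicus as the target (a higher number here means a more potent compound, by a factor of ten per unit of this negative logarithm, a lower number a less potent compound), compound 3 stands highest of the three numbers, but its steps to the others are small: a number 0.02 log units higher from compound 1 to compound 3 (within the scatter) and a number 0.15 log units higher from compound 2 to compound 3 (within the scatter), both within the scatter, so no ordering among compounds 1, 2 and 3 can be read from these values.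

Compound 4 `CC1(C)C=C(n2ccccc2=O)c2cc(C(=O)c3ccc([N+](=O)[O-])cc3)ccc2O1` is next. nitro in place of hydroxy on an aromatic carbon Two measured steps touch the same part of the structure. a number 0.13 log units lower from compound 1 to compound 2 (within the scatter) and a number 0.02 log units higher from compound 1 to compound 3 (within the scatter) replace ethyl on the carbonyl carbon by a substituted phenyl with no change beyond the scatter, and a number 0.15 log units higher from compound 2 to compound 3 (within the scatter) alters the group on that aromatic carbon, again within the scatter. Nothing measured distinguishes one group on that aromatic carbon from another, so for compound 4 a step of a number 0.02 log units lower from compound 3 to compound 4 (within the scatter) is expected, that is, none beyond the scatter, with the range widened because nitro has not appeared in this series. Compound 4 is therefore estimated at 5.85, between 5.35 and 6.35.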

Compound 4, logarithm of the reciprocal of the active concentration, log(1/C): 6.09
Compound 4: middle estimate off by 0.24 log units, on the low side; the measured number falls inside the stated range.
By their numbers in this assay, from the lowest: compounds 2, 1, 3 and 4 (each within the scatter of the next, the first and the last beyond it).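

In this assay, among the compounds shown here, the group on this aromatic carbon now makes a readable difference for the first time: the step of a number 0.37 log units higher from compound 2 to compound 4 (beyond the scatter) is the only one that passes the scatter, and it is modest. The other two steps stay within the scatter, a number 0.22 log units higher from compound 3 to compound 4 (within the scatter) and a number 0.24 log units higher from compound 1 to compound 4 (within the scatter), so nitro is separated from methoxy but not from hydroxy, and 4-nitrophenyl is not separated from ethyl on the carbonyl carbon. No measurement here accounts for the separation of nitro from methoxy.

The compounds shown leave open how an amine or a carboxylic acid on this aromatic carbon would read. They also leave open whether a longer chain in place of ethyl on the carbonyl carbon would move the number at all.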